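Compound 4: methyl in place of 4-chlorophenyl

The compounds below may be only part of what the source reports. "The series", "measured", "known", "first", "only" and "open" are said of these compounds alone.

Within the data shown here, compound 1 `O=C(OC1(C(=O)Nc2ccc([N+](=O)[O-])cc2)CCCCC1)c1ccc(Cl)cc1` gives 355 nM in an ADME assay on WI-38 cells (Homo sapiens) for inhibition, read by MTT assay, with a stated time of 72 h (a higher number here means a weaker inhibitor, a lower number a stronger inhibitor), and holds the lowest of the three numbers so far, though both neighbours sit within the scatter: compound 2 `O=C(OC1(C(=O)Nc2ccc([N+](=O)[O-])cc2)CCCCC1)c1ccc(Br)cc1` gives 523 nM, a step of a 1.5-fold higher number from compound 1 to compound 2 (0.17 log units; within the scatter), and compound 3 `O=C(OC1(C(=O)Nc2ccc([N+](=O)[O-])cc2)CCCCC1)c1ccccc1I` gives 396 nM, a step of a 1.1-fold higher number from compound 1 to compound 3 (0.05 log units; within the scatter). Between compound 2 and compound 3 the step is a 1.3-fold lower number from compound 2 to compound 3 (0.12 log units; within the scatter). Compound 4 `CC(=O)OC1(C(=O)Nc2ccc([N+](=O)[O-])cc2)CCCCC1` differs from compound 1 by methyl in place of 4-chlorophenyl on a carbonyl carbon. Among the measured compounds shown here, none of the measured steps bears directly on this change: each of them keeps a phenyl ring on the carbonyl carbon and alters only the halogen it carries, and all three stay within the scatter, so the series gives no guide to removing the ring altogether. The three measured compounds cluster closely; the change to acetyl is of a different kind, and the expectation here is a higher number, with wide uncertainty. The step from compound 1 to compound 4 is expected to be a 2.5-fold higher number from compound 1 to compound 4 (0.40 log units; beyond the scatter). Compound 4 is therefore estimated at 900 nM, with a range from 300 nM to 3000 nM.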

Compound 4, half-maximal inhibitory concentration: 386 nM
For compound 4 the middle estimate is 2.3-fold (0.37 log units) above the measured one; the measured number falls inside the stated range.
By their numbers in this assay, from the lowest: compounds 1, 4, 3 and 2 (each within the scatter of the next).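

Methyl in place of the aryl group on the carbonyl carbon reads the same against all three aryl compounds in this assay: (a 1.1-fold higher number from compound 1 to compound 4 (0.04 log units; within the scatter)) and (a 1.0-fold lower number from compound 3 to compound 4 (0.01 log units; within the scatter)) and (a 1.4-fold lower number from compound 2 to compound 4 (0.13 log units; within the scatter)). The earlier compounds showed only that the halogen and its place on a phenyl ring could vary within the scatter, whereas this result shows that, among these four compounds, the whole ring can give way to methyl with no step beyond it. No measurement shown accounts for this flat reading.

From the compounds shown here alone, whether this tolerance extends to a longer alkyl chain, or to a chain ending in an amine or a carboxylic acid, stays open. Going by these compounds, the shared core is constant throughout, so its contribution to the reading also stays open.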